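The source may hold more compounds than are shown below. What is called first, only, known or untested is meant among the compounds shown, and "the series" means these compounds.

Measured in a functional assay on L1210 cells (Mus musculus); a lower number here means a stronger inhibitor, a higher number a weaker inhibitor:
- Compound 1 `CNC[C@H]1OC(n2cnc3c(N)ncnc32)[C@H](O)[C@@H]1O`: > 600000 nM, a limit
- Compound 2 `CN(Cc1ccc(CN)cc1)C[C@H]1OC(n2cnc3c(N)ncnc32)[C@H](O)[C@@H]1O`: > 600000 nM, a limit

Compound 2 has no numeric value in this assay, only the limit of > 600000 nM. The same limit applies to both measured compounds: the limit of > 600000 nM in this assay, at which 2 of the 2 values shown sit.

Compound 3 `CN(Cc1ccccc1CN)C[C@H]1OC(n2cnc3c(N)ncnc32)[C@H](O)[C@@H]1O` is an isomer of compound 2, with 2-(aminomethyl)phenyl in place of 4-(aminomethyl)phenyl on a saturated chain carbon bound to an amine nitrogen.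

Within the data shown here, the only measured step that bears on this change is a step that the two limits leave unreadable from compound 1 to compound 2. It has no readable size, so it offers no measured basis for a shift in either direction. No step beyond the scatter is therefore expected in this assay, and another limit is the likeliest report. The expected change is a number no higher from compound 2 to compound 3 (the limit leaves the size open). Compound 3 is estimated at 600000 nM, with an expected range of 200000 nM to 1500000 nM.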

Compound 3, half-maximal inhibitory concentration: > 600000 nM
Compound 3 gave a limit, no number; the forecaster's own chance of this, stated with the estimate: 80%; the middle value lies on the limit itself.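

In this assay compound 3 gives > 600000 nM, a limit and not a number. Among these compounds, no step among compound 1, compound 2 and compound 3 can be read, and all sit at one limit: the limit of > 600000 nM in this assay, at which 3 of the 3 values shown sit. On these data alone, whether 4-(aminomethyl)benzyl and 2-(aminomethyl)benzyl differ in this read-out stays open.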